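A few compounds are considered here, and "the series" means these few. Any claim that something is new, unique, unknown or untested is made for them only; others in the source may bear on it.

Measured in a functional assay on EBC-1 cells (Homo sapiens) for antiproliferative activity, read by sulforhodamine B assay, with a stated time of 72 h; on this read-out lower numbers stand for stronger inhibition and higher numbers for weaker inhibition:
- compound 1 `Cn1cc(-c2ccc(=O)n(CCOc3ccnc4cc(OCCCCCC(=O)NO)ccc34)n2)cn1`: 460 nM
- compound 2 `Cn1cc(-c2ccc(=O)n(CCOc3ccnc4cc(OCCCCCCC(=O)NO)ccc34)n2)cn1`: 210 nM
- compound 3 `Cn1cc(-c2ccc(=O)n(CCOc3ccnc4cc(OCCCCCC(=O)Nc5ccccc5N)ccc34)n2)cn1`: 370 nM

Compound 3 stands within the scatter of both others: a 1.2-fold lower number from compound 1 to compound 3 (0.09 log units; within the scatter) and a 1.8-fold higher number from compound 2 to compound 3 (0.25 log units; within the scatter). Within the data shown here, the one step beyond the scatter is modest: a 2.2-fold lower number from compound 1 to compound 2 (0.34 log units; beyond the scatter).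

Compound 4 `CC(=O)CCCCCOc1ccc2c(OCCn3nc(-c4cnn(C)c4)ccc3=O)ccnc2c1` carries methyl in place of (2-aminophenyl)amino on a carbonyl carbon. The nearest evidence is the chain-end exchange a 1.2-fold lower number from compound 1 to compound 3 (0.09 log units; within the scatter), which is small. Among the measured compounds shown here, no measured compound ends in acetyl, so this support is weak and the range is kept wide. No step beyond the scatter is expected in this assay. The expected step is a 1.1-fold higher number from compound 3 to compound 4 (0.03 log units; within the scatter). Compound 4 is estimated at 400 nM, with an expected range of 120 nM to 1300 nM.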

Compound 4, half-maximal inhibitory concentration: 25 nM
For compound 4 the middle estimate is 16-fold (1.20 log units) above the measured one, and the stated range ends above it.
By their numbers in this assay, from the lowest: compound 4; then compounds 2, 3 and 1 (each within the scatter of the next, the first and the last beyond it).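

In this assay the group on the carbonyl carbon carries far more weight than the exchange between hydroxyamino and (2-aminophenyl)amino suggested: methyl in place of (2-aminophenyl)amino gives a large gain (a 15-fold lower number from compound 3 to compound 4 (1.17 log units; beyond the scatter)), and methyl in place of hydroxyamino gives a similar one (an 18-fold lower number from compound 1 to compound 4 (1.26 log units; beyond the scatter)). The gain also holds against the longer hydroxamic acid chain, with acetyl in place of (hydroxycarbamoyl)methyl (an 8.4-fold lower number from compound 2 to compound 4 (0.92 log units; beyond the scatter)), so neither chain end is required for antiproliferative activity here. No measurement available here accounts for the gain.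

From the compounds shown here alone, whether a carboxylic acid or primary amide at the chain end matches acetyl stays open, as does whether a longer chain ending in acetyl holds the gain.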